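A few compounds are considered here, and "the series" means these few. Any claim that something is new, unique, unknown or untested is made for them only; others in the source may bear on it.

Working notes on a small set sharing one core.

Within the data shown here, compound 1 `COc1cc(/C=C/C(=O)Nc2cc3c(Nc4ccc(F)c(Cl)c4)ncnc3cc2O[C@H]2CCOC2)cc(OC)c1OC` is the only member with a numerical reading in a functional assay on A549 cells (Homo sapiens) for cytotoxicity, read by MTT assay, with a stated time of 72 h; on this read-out lower numbers stand for stronger inhibition and higher numbers for weaker inhibition: compound 1 gives 4150 nM. Compound 2 `COc1cc(/C=C/C(=O)Nc2cc3c(Nc4ccc(F)c(Cl)c4)ncnc3cc2OC)cc(OC)c1` is reported in this assay only as "not active" (no number reported), with no number attached. Compound 3 `COc1cc2ncnc(Nc3ccc(F)c(Cl)c3)c2cc1NC(=O)/C=C/c1cc(OC)c(OC)c(OC)c1` is likewise recorded in this assay as "not active" (no number reported), again without a number. Among the measured compounds shown here, neither of these two differs from compound 1 in a single place, so no step between measured compounds can be sized; what the entries show is simply that the single numerical reading in the set belongs to compound 1 alone, and that the other two entries offer no number against which to set it.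

Compound 4 `COc1ccc(/C=C/C(=O)Nc2cc3c(Nc4ccc(F)c(Cl)c4)ncnc3cc2O[C@H]2CCOC2)cc1` has not yet been measured. Relative to compound 1 it carries 4-methoxyphenyl in place of 3,4,5-trimethoxyphenyl on a double-bonded chain carbon bound to a double-bonded chain carbon. For the measured compounds named here, no measured pair sizes this change, so the expectation rests only on the single reading of compound 1 and on the absence of numbers elsewhere. The step expected in this assay is a 2.2-fold higher number from compound 1 to compound 4 (0.34 log units; beyond the scatter), reaching beyond the scatter toward weaker inhibition, though a step within the scatter cannot be excluded. Compound 4 is accordingly estimated at 9000 nM in this assay, with a range from 3000 nM to 30000 nM, and a real chance that only a limit is reported.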

Compound 4, half-maximal inhibitory concentration: 3050 nM
Beside the measured number, compound 4's estimate is 3.0-fold (0.47 log units) above it, within the range that was stated.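

In this assay, among these compounds, the exchange of 3,4,5-trimethoxyphenyl for 4-methoxyphenyl on a double-bonded chain carbon bound to a double-bonded chain carbon gives a 1.4-fold lower number from compound 1 to compound 4 (0.13 log units; within the scatter) and so leaves the two readings indistinguishable, which makes this the first sized step in the set. The group that leaves holds 12 heavy atoms and 3 hydrogen-bond acceptors, the group that enters holds 8 heavy atoms and 1 hydrogen-bond acceptor, and in this pair that difference does not separate the two compounds. No supporting data bear on why the readings stay together across this change.

As far as these compounds go, whether this place tolerates other groups remains open: a plain phenyl, a pyridine ring, or a phenyl carrying an amine or a carboxylic acid could fall with compound 4 or well away from it. Among the compounds shown here, also open is whether the same exchange gives a similar step when the rest of the core of compound 1 is changed, since the single pair here speaks only for that one background.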